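Isobutyl to sec-butyl on the amide-bearing chain carbon

The source may report more compounds than this note shows. Statements on the series, on what has been measured and on what is new or still open speak of the compounds shown alone.

Compound 2 `CC(=O)c1ccc(NC(=O)C(CC(C)C)N(C(=O)c2ccccc2)S(=O)(=O)c2ccc(C)cc2)cc1` stands highest of the two numbers in a functional assay for inhibition, read by spectrophotometry, with a stated time of 20 min, tested at 2 mg/mL (on this read-out lower numbers stand for a weaker effect and higher numbers for a stronger effect at the one concentration tested), where compound 2 gives 58.1%; compound 1 `CC(=O)c1ccc(NC(=O)CN(C(=O)c2ccccc2)S(=O)(=O)c2ccc(C)cc2)cc1` gives 18.1%. Among the compounds with values here, the only measured step is a number 40 percentage points higher from compound 1 to compound 2 (beyond the scatter). Compound 3 `CCC(C)C(C(=O)Nc1ccc(C(C)=O)cc1)N(C(=O)c1ccccc1)S(=O)(=O)c1ccc(C)cc1` differs from compound 2 by sec-butyl in place of isobutyl on a saturated chain carbon bound to an amide-type nitrogen and a carbonyl carbon. Within the data shown here, no measured step exchanges one four-carbon chain for another; the step from compound 1 to compound 2 shows only that a chain at this place matters, not how two chains compare. The expectation is therefore a step within the scatter, a number 4.1 percentage points lower from compound 2 to compound 3 (within the scatter). Compound 3 is estimated at 54%, in the range 34% to 72%.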

Compound 3, a percentage reported as inhibition, at one concentration (the size of the read-out at that concentration, not a potency): 25.7%
Beside the measured number, compound 3's estimate is 28.3 percentage points above it; measured number outside the range, below it.
By their numbers in this assay, from the lowest: compounds 1 and 3 (each within the scatter of the next); then compound 2.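

In this assay this place separates two chains with the same atoms: sec-butyl in place of isobutyl gives a number 32.4 percentage points lower from compound 2 to compound 3 (beyond the scatter) on a saturated chain carbon bound to an amide-type nitrogen and a carbonyl carbon. Set against hydrogen, sec-butyl gives a number 7.6 percentage points higher from compound 1 to compound 3 (within the scatter), so the gain seen with isobutyl does not extend to every four-carbon chain here. Nothing available explains the difference between these two chains.

Still open, from the compounds shown here alone, is how a longer chain or a benzyl group at this place would compare with isobutyl. Going by these compounds, the effect of an amine or a carboxylic acid on this chain also remains unknown.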